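A few compounds are considered here, and "the series" means these few. Any claim that something is new, unique, unknown or untested is made for them only; others in the source may bear on it.

Compound 2 `O=S(=O)(Nc1ccc2oc(-c3ccccc3)nc2c1)c1ccc(Cl)cc1` sits at the ceiling of an assay on cells for inhibition of HSP60/HSP10 (Homo sapiens), with a stated time of 60 min; a higher number here means a weaker inhibitor, a lower number a stronger inhibitor: in this assay compound 2 gives only the limit > 100000 nM, not a number. Compound 1 `O=S(=O)(Nc1ccc2oc(-c3ccccc3)nc2c1)c1ccccc1F` stands at the same ceiling; in this assay compound 1 gives > 100000 nM, again a limit. Among the compounds with values here, the one measured step, a step that the two limits leave unreadable from compound 1 to compound 2, is therefore unreadable, and the limit of > 100000 nM in this assay, at which 2 of the 2 values shown sit, holds both values shown. Compound 3 `O=S(=O)(Nc1ccc2oc(-c3ccccc3)nc2c1)c1cccc(O)c1` differs from compound 2 by 3-hydroxyphenyl in place of 4-chlorophenyl on a sulfonyl sulfur. Within the data shown here, the only step that bears on this position is the unreadable one from compound 1 to compound 2, so it offers no size and no direction, and the two compounds measured so far say only that this assay has not yet registered any inhibition from the series. The estimate for compound 3 is therefore anchored at the limit: compound 3 is expected at 100000 nM, within 30000 nM to 300000 nM. The expected step of a number no higher from compound 2 to compound 3 (the limit leaves the size open) is of no size beyond the scatter.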

Compound 3, half-maximal inhibitory concentration: 76000 nM
Estimate against measurement, compound 3: 1.3-fold (0.12 log units) above, within the range that was stated.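

In this assay the position on the sulfonyl sulfur now gives a first number instead of a limit, and it does so with 3-hydroxyphenyl, which carries a hydrogen-bond donor and acceptor that 4-chlorophenyl lacks. The readable steps are an at least 1.3-fold lower number from compound 2 to compound 3 (0.11 log units; that floor lies within the scatter) and an at least 1.3-fold lower number from compound 1 to compound 3 (0.11 log units; that floor lies within the scatter); both are floors, so neither shows a change beyond the scatter, although the true sizes may be larger. The other two compounds remain at a limit of the assay: the limit of > 100000 nM in this assay, at which 2 of the 3 values shown sit.

As far as these compounds go, whether the reading depends on the hydroxyl itself remains open, as does how 3-methoxyphenyl, 3-aminophenyl or 3-carboxyphenyl would read on the same sulfonyl sulfur. Any real inhibition at this position also remains to be separated from the scatter by a compound reading well under this ceiling.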